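From naphthalen-1-yl to 2,6-difluorophenyl in compound 3

This account rests on a few compounds, and the source may have more. Where it says the series, first, only, none or still open, it means among the compounds named here.

Compound 1 (`COc1ccc(CSc2nc(Cc3c(Cl)cccc3Cl)c(C)c(=O)[nH]2)cc1`): 32000 nM
Compound 2 (`COc1ccc(C(=O)CSc2nc(Cc3cccc4ccccc34)c(C(C)C)c(=O)[nH]2)cc1`): 203000 nM

In an ADME assay on MT4 cells (Homo sapiens) for cytotoxicity, read by MTT assay (on this read-out lower numbers stand for higher toxicity in this test and higher numbers for lower toxicity in this test), compound 2 stands highest of the two at 203000 nM, and compound 1 gives 32000 nM. The gap between these two numbers lies beyond the scatter. Compound 3 (`COc1ccc(C(=O)CSc2nc(Cc3c(F)cccc3F)c(C(C)C)c(=O)[nH]2)cc1`) differs from compound 2 in one place (2,6-difluorophenyl in place of naphthalen-1-yl on a saturated chain carbon bound to an aromatic carbon): 2,6-difluorophenyl in place of naphthalen-1-yl on a saturated chain carbon bound to an aromatic carbon. Among the compounds with values here, no measured pair shows this change alone, so the expectation is loose. A modest move towards a lower number is expected (a 1.8-fold lower number from compound 2 to compound 3 (0.27 log units; within the scatter)). Compound 3 is estimated at 110000 nM (expected range 35000 nM to 300000 nM).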

Compound 3, half-maximal cytotoxic concentration: 33000 nM
Compound 3: the middle estimate sits 3.3-fold (0.52 log units) above what was measured; measured number outside the range, below it.
By their numbers in this assay, from the lowest: compounds 1 and 3 (each within the scatter of the next); then compound 2.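

In this assay, within the data shown here, the move from naphthalen-1-yl to 2,6-difluorophenyl on a saturated chain carbon bound to an aromatic carbon gives a 6.2-fold lower number from compound 2 to compound 3 (0.79 log units; beyond the scatter), the first step here that isolates a single place. It shows that this place alone can shift the number beyond the scatter, towards higher toxicity in this test. Nothing at hand bears on the reason for this step. The compounds shown leave open whether the fluorines or the loss of one aromatic ring drive the shift. A plain phenyl or a pyridine at this place could separate the two.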